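The compounds below may be only part of what the source reports. "The series", "measured", "known", "first", "only" and "open" are said of these compounds alone.

Compound 3, `O=C(CSc1nc2c(c(=O)n1-c1ccc(F)cc1)SCC2)Nc1nc2ccc(Cl)cc2s1`, gives 175 nM in an assay on L cells for inhibition of Protein-serine O-palmitoleoyltransferase porcupine (Mus musculus), read by reporter gene assay, with a stated time of 24 h; a lower number here means that less compound is needed, a higher number that more compound is needed for the effect. Among the compounds with values here, that is the highest of the three numbers measured so far: compound 1, `O=C(CSc1nc2c(c(=O)n1-c1ccccc1)SCC2)Nc1nc2ccc(Cl)cc2s1`, gives 40 nM, and compound 2, `COc1ccccc1-n1c(SCC(=O)Nc2nc3ccc(C(F)(F)F)cc3s2)nc2c(c1=O)SCC2`, gives 30 nM. Within the data shown here, the only measured step that changes a single place is a 4.4-fold higher number from compound 1 to compound 3 (0.64 log units; beyond the scatter), which was a fluoro in place of hydrogen on an aromatic carbon.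

Compound 4 is `COc1ccccc1-n1c(SCC(=O)Nc2nc3ccc(Cl)cc3s2)nc2c(c1=O)SCC2`. The change from compound 3 to compound 4 is 2-methoxyphenyl in place of 4-fluorophenyl on an aromatic nitrogen. This change removes the fluoro that raised the number in the measured step and at the same time puts in the methoxy-bearing ring that compound 2 carries. Among the measured compounds shown here, no measured step covers this exact exchange, so the expectation rests on two things: the measured step shows that removing the fluorine returns the number to the level of compound 1, and compound 2, which carries the same 2-methoxyphenyl on the same nitrogen together with a trifluoromethyl instead of chloro, sits in the same low range. Compound 4 is therefore expected to fall back from the value of compound 3, by a step of about a 4.4-fold lower number from compound 3 to compound 4 (0.64 log units; beyond the scatter), to an estimated 40 nM, in a range from 15 nM to 110 nM.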

Compound 4, half-maximal effective concentration: 50 nM
The estimate for compound 4 lay 1.3-fold (0.10 log units) below the measured number; the measured number falls inside the stated range.
By their numbers in this assay, from the lowest: compounds 2, 1 and 4 (each within the scatter of the next); then compound 3.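

In this assay, the number rises when 4-fluorophenyl sits on the aromatic nitrogen, but 2-methoxyphenyl at that place shows no such rise: exchanging one for the other gives a clear drop (a 3.5-fold lower number from compound 3 to compound 4 (0.54 log units; beyond the scatter)), while comparison with the unsubstituted phenyl stays within the usual scatter (a 1.3-fold higher number from compound 1 to compound 4 (0.10 log units; within the scatter)), so this position accepts a methoxy in the 2-methoxyphenyl arrangement with no measurable change. With 2-methoxyphenyl in place, the chloro and trifluoromethyl groups on the other end of the molecule also cannot be told apart (a 1.7-fold higher number from compound 2 to compound 4 (0.22 log units; within the scatter)), a difference that again lies within the scatter. Nothing available explains why 4-fluorophenyl and 2-methoxyphenyl behave differently here.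

Still open, on these data alone, is whether the higher number goes with fluoro itself or with its place on the ring, a question that 2-fluorophenyl and 4-methoxyphenyl on the same nitrogen could help to separate. As far as these compounds go, it is also open how far this position stretches beyond these groups, for example to a phenyl ring carrying an amine or a carboxylic acid.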